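The source may hold more compounds than are shown below. What is called first, only, known or untested is meant among the compounds shown, and "the series" means these compounds.

Compound 3 `C(=C\C1CCCN(CCCCc2ccccc2)C1)\c1ccccc1` gives 7 nM in an assay on isolated protein for binding affinity to Sigma non-opioid intracellular receptor 1 (Rattus norvegicus); a lower number here means a stronger inhibitor, a higher number a weaker inhibitor. That number is level with compound 2 `C(=C\C1CCCN(CCC2CCCCC2)C1)\c1ccccc1`, which gives 7 nM, and together these two are the highest of the three values seen, while compound 1 `CC(C)=CCN1CCCC(/C=C\c2ccccc2)C1` gives 1 nM. The step of a 7.0-fold higher number from compound 1 to compound 2 (0.85 log units; beyond the scatter) went beyond the scatter, whereas the step of no change at the digits printed from compound 2 to compound 3 (within the scatter) stayed within it. Compound 4 `C(=C\C1CCCN(CCCOc2ccccc2)C1)\c1ccccc1` carries phenoxy in place of benzyl on a saturated chain carbon, three bonds along the chain from an amine nitrogen in a ring. Among the measured compounds shown here, no measured step puts an oxygen into this chain, so the nearest guide is no change at the digits printed from compound 2 to compound 3 (within the scatter), where exchanging one chain end for another of similar size left the number within the scatter. Compound 4 is therefore expected to give about 7 nM, most likely between 2 nM and 25 nM, an expected step of no change at the digits printed from compound 3 to compound 4 (within the scatter).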

Compound 4, half-maximal inhibitory concentration: 15 nM
Compound 4: the middle estimate sits 2.1-fold (0.33 log units) below what was measured; the range from low to high includes it.
By their numbers in this assay, from the lowest: compound 1; then compounds 2 and 3 (each within the scatter of the next); then compound 4.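

In this assay, exchanging benzyl for phenoxy on a saturated chain carbon, three bonds along the chain from an amine nitrogen in a ring, gives a 2.1-fold higher number from compound 3 to compound 4 (0.33 log units; beyond the scatter), so this position does respond to a swap that keeps the heavy-atom count and adds one hydrogen-bond acceptor. Phenoxymethyl in place of cyclohexyl gives a 2.1-fold higher number from compound 2 to compound 4 (0.33 log units; beyond the scatter), a change that the earlier chain-end exchange did not show. Nothing measured here accounts for this shift. Still open, from the compounds shown here alone, is how an amine in place of that oxygen, or a longer chain before the phenoxy, would read.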